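The source may hold more compounds than are shown below. What is called first, only, known or untested is meant among the compounds shown, and "the series" means these compounds.

In an ADME assay on Vero cells (Chlorocebus sabaeus) for cytotoxicity, read by MTT assay, with a stated time of 96 h (on this read-out lower numbers stand for higher toxicity in this test and higher numbers for lower toxicity in this test), compound 1 `COc1ccc(-c2cnco2)cc1NCc1ccc(C)s1` gives 42700 nM, compound 3 `COc1ccc(-c2cnco2)cc1NCc1cccs1` gives 53800 nM and compound 2 `COc1cc(NCc2scnc2C)ccc1-c1cnco1` gives 73700 nM, so compound 2 lies within the scatter of both others. Compound 4 `COc1cc(NCc2ccsc2)ccc1-c1cnco1` differs from compound 2 as follows: thiophen-3-yl in place of 4-methyl-1,3-thiazol-5-yl on a saturated chain carbon bound to a nitrogen on an aromatic ring. This places thiophen-3-yl where 4-methyl-1,3-thiazol-5-yl stood. Among the compounds with values here, no measured step covers this exchange. The nearest evidence is a 1.3-fold higher number from compound 1 to compound 3 (0.10 log units; within the scatter), for hydrogen in place of methyl on an aromatic carbon, and it bears only indirectly. No step beyond the scatter is therefore expected in this assay. The estimated change is a 1.2-fold lower number from compound 2 to compound 4 (0.09 log units; within the scatter). For compound 4 the expected value is 60000 nM, with an estimated range of 32000 nM to 105000 nM.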

Compound 4, half-maximal cytotoxic concentration: 181000 nM
Estimate against measurement, compound 4: 3.0-fold (0.48 log units) below, and the stated range ends below it.
By their numbers in this assay, from the lowest: compounds 1, 3 and 2 (each within the scatter of the next); then compound 4.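

In this assay the position on a saturated chain carbon bound to a nitrogen on an aromatic ring gives the first step beyond the scatter among these compounds: a 2.5-fold higher number from compound 2 to compound 4 (0.39 log units; beyond the scatter) for thiophen-3-yl in place of 4-methyl-1,3-thiazol-5-yl. Within the data shown here, the only earlier step, a 1.3-fold higher number from compound 1 to compound 3 (0.10 log units; within the scatter) for hydrogen in place of methyl, did not show this. The exchange changes the ring and removes the methyl together, so the two parts cannot be separated here.

Open, on these data alone, is how 1,3-thiazol-5-yl without the methyl, or an amine at this place, would read. The data shown give no reason for the step.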